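Shifting a Chlorine Atom Around a Dichlorophenyl Ring

The compounds below may be only part of what the source reports. "The series", "measured", "known", "first", "only" and "open" are said of these compounds alone.

Compound 1 `CNC(=O)c1cc(Oc2ccc(C(=O)/C=C/c3ccc(Cl)cc3Cl)cc2)ccn1` was tested in a functional assay on HepG2 cells (Homo sapiens) for cytotoxicity, read by MTT assay, with a stated time of 72 h (on this read-out lower numbers stand for stronger inhibition and higher numbers for weaker inhibition), where compound 1 gives 11700 nM. Compound 2 `CNC(=O)c1cc(Oc2ccc(C(=O)/C=C/c3ccc(OC)c(OC)c3OC)cc2)ccn1` gives 9810 nM in this assay. Compound 1 has the larger of these two numbers, but the gap sits within the scatter, so the two cannot be told apart. Compound 3 `CNC(=O)c1cc(Oc2ccc(C(=O)/C=C/c3ccc(Cl)c(Cl)c3)cc2)ccn1` has not been measured. It differs from compound 1 by 3,4-dichlorophenyl in place of 2,4-dichlorophenyl on a double-bonded chain carbon bound to a double-bonded chain carbon. Within the data shown here, no comparable step between measured compounds exists to guide this change, so a step of a 1.1-fold lower number from compound 1 to compound 3 (0.03 log units; within the scatter) is expected, no larger than the scatter. For compound 3 the estimate is 11000 nM, within a range from 4500 nM to 27000 nM.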

Compound 3, half-maximal inhibitory concentration: 11400 nM
The estimate for compound 3 lay 1.0-fold (0.02 log units) below the measured number; the measured number falls inside the stated range.
By their numbers in this assay, from the lowest: compounds 2, 3 and 1 (each within the scatter of the next).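

Moving one chlorine atom, so that 3,4-dichlorophenyl replaces 2,4-dichlorophenyl, gives a 1.0-fold lower number from compound 1 to compound 3 (0.01 log units; within the scatter) in this assay. Among these compounds, this is the first direct comparison at this position, and for these two compounds, which have the same atoms joined differently, the change leaves no difference that can be told from scatter. Nothing measured here accounts for this result.

From the compounds shown here alone, it remains open whether a ring with a single chlorine atom, or with fluorine atoms or an amine instead of chlorine, would behave the same way. Changes elsewhere on the shared core also remain untested by these compounds.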